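A few compounds are considered here, and "the series" means these few. Any claim that something is new, unique, unknown or untested is made for them only; others in the source may bear on it.

Working notes on the series. In an assay for binding affinity to melatonin receptor (Gallus gallus) (on this read-out lower numbers stand for stronger inhibition and higher numbers for weaker inhibition), compound 2 `CC(=O)NCCCc1cccc(Br)c1` gives 852 nM, the higher of the two numbers recorded so far. Compound 1 `CCCC(=O)NCCCc1cccc(Cl)c1`, the nearest point, gives 113 nM in this assay. Compound 3 `CCCC(=O)NCCCc1cccc(Br)c1` is not yet measured; it differs from compound 2 by ethyl in place of hydrogen on a saturated chain carbon bound to a carbonyl carbon. Compound 3 carries the same acyl group as compound 1, so the number in this assay for compound 3 is expected to move down by about a 6.6-fold lower number from compound 2 to compound 3 (0.82 log units; beyond the scatter), beyond the scatter. The estimate for compound 3 in this assay is 130 nM, with a range from 50 nM to 350 nM.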

Compound 3, inhibition constant: 354 nM
Estimate against measurement, compound 3: 2.7-fold (0.44 log units) below; measured number outside the range, above it.
By their numbers in this assay, from the lowest: compound 1; then compound 3; then compound 2.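

In this assay, the step of a 2.4-fold lower number from compound 2 to compound 3 (0.38 log units; beyond the scatter) for ethyl in place of hydrogen on a saturated chain carbon bound to a carbonyl carbon shows that this position affects the number with bromo held fixed, though the step is modest. The step of a 3.1-fold higher number from compound 1 to compound 3 (0.50 log units; beyond the scatter) for bromo in place of chloro on an aromatic carbon shows that the halogen also matters with the acyl group held fixed. No data here explain either step. From the compounds shown here alone, whether a chain longer than propylcarbonyl lowers the number further remains open, as does how fluoro or methoxy on that aromatic carbon compares with chloro and bromo.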